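The compounds below may be only part of what the source reports. "The series", "measured", "known", "first", "only" and "open" are said of these compounds alone.

Three compounds built on one shared core were tested in a functional assay on the whole organism (artery, strain albino) with Rattus norvegicus as the target, with a stated time of 300 min, at a dose of 10 mg/kg by the oral route; on this read-out lower numbers stand for less inhibition and higher numbers for more inhibition at the one dose given (going by the name of the read-out). Compound 1 `COc1ccc(C2N=C(SCc3ccccc3)NC(C)=C2C(=O)Nc2ccc(F)cc2)cc1OC` gives 7.2%, compound 2 `COc1ccc(C2N=C(SCc3ccccc3Cl)NC(C)=C2C(=O)Nc2ccc(F)cc2)cc1OC` gives 35.9%, and compound 3 `COc1ccc(C2N=C(SCc3cccc(Cl)c3)NC(C)=C2C(=O)Nc2ccc(F)cc2)cc1OC` gives 16.4%. Compound 3 stands second highest of the three numbers: the nearer gap is a number 9.2 percentage points higher from compound 1 to compound 3 (within the scatter) and the wider one is a number 19.5 percentage points lower from compound 2 to compound 3 (beyond the scatter). Compound 4 `COc1ccc(C2N=C(SCc3ccc(Cl)cc3)NC(C)=C2C(=O)Nc2ccc(F)cc2)cc1OC` differs from compound 3 by 4-chlorophenyl in place of 3-chlorophenyl on a saturated chain carbon bound to a sulfur. For the measured compounds named here, the only measured step that moves the chloro around its ring is the one from compound 2 to compound 3, of modest size, and a number 28.7 percentage points higher from compound 1 to compound 2 (beyond the scatter) shows the largest effect seen. Nothing measured covers the new position, so no step beyond the scatter is expected. Compound 4 is therefore estimated at 18%, within 5% to 34%. The expected step is a number 1.6 percentage points higher from compound 3 to compound 4 (within the scatter).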

Compound 4, a percentage reported as inhibition, in the whole organism at one dose (the size of the read-out at that dose, not a potency): 31.3%
For compound 4 the middle estimate is 13.3 percentage points below the measured one, within the range that was stated.
By their numbers in this assay, from the lowest: compounds 1 and 3 (each within the scatter of the next); then compounds 4 and 2 (each within the scatter of the next).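

The change to 4-chlorophenyl on the saturated chain carbon bound to a sulfur gives a number 14.9 percentage points higher from compound 3 to compound 4 (beyond the scatter) and so shows that the placement of the chloro matters beyond the 3-chlorophenyl result alone. The 2-chlorophenyl and 4-chlorophenyl groups do not separate, with a number 4.6 percentage points lower from compound 2 to compound 4 (within the scatter) as the step between them, while adding the chloro in the 4-chlorophenyl form gives a number 24.1 percentage points higher from compound 1 to compound 4 (beyond the scatter) and compound 3 remains the chloro compound that goes against this rise. No evidence here explains this difference between placements.

From the compounds shown here alone, whether a bromo, a methoxy or an amine in place of the chloro would follow the same order stays open. So does whether a longer chain between the sulfur and the ring would keep these numbers.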